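From 2,6-dichlorophenyl to 3,5-difluorophenyl on a shared core

The source may report more compounds than this note shows. Statements on the series, on what has been measured and on what is new or still open speak of the compounds shown alone.

Within the data shown here, in a functional assay on PC-3 cells (Homo sapiens) for inhibition, read by MTT assay, with a stated time of 48 h, tested at 10 uM (on this read-out higher numbers stand for more inhibition of growth at the one concentration tested and lower numbers for less inhibition of growth), compound 3 (`Cc1oc2c([C@H]3CCN(C)C[C@H]3O)c(O)cc(O)c2c(=O)c1C(O)c1c(Cl)cccc1Cl`) gives 0%, the lowest of the three numbers so far. Compound 1 (`Cc1oc2c([C@H]3CCN(C)C[C@H]3O)c(O)cc(O)c2c(=O)c1C(O)c1ccccc1Br`) gives 45%, and compound 2 (`Cc1oc2c([C@H]3CCN(C)C[C@H]3O)c(O)cc(O)c2c(=O)c1C(O)c1ccc(F)c(Br)c1`) gives 72%. Compound 4 (`Cc1oc2c([C@H]3CCN(C)C[C@H]3O)c(O)cc(O)c2c(=O)c1C(O)c1cc(F)cc(F)c1`) has 3,5-difluorophenyl in place of 2,6-dichlorophenyl on a saturated chain carbon bound to an aromatic carbon and an oxygen on a saturated carbon. Among the measured compounds shown here, two measured steps bear on this change, a number 45 percentage points lower from compound 1 to compound 3 (beyond the scatter) and a number 72 percentage points lower from compound 2 to compound 3 (beyond the scatter). Both are large and both end at 2,6-dichlorophenyl, so a large step in the opposite direction is expected on leaving that group. The expected step is a number 52 percentage points higher from compound 3 to compound 4 (beyond the scatter). The estimate for compound 4 is 52%, with an expected range of 25% to 80%.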

Compound 4, percent growth inhibition at one concentration: 0%
Compound 4: the middle estimate sits 52 percentage points above what was measured, and the stated range ends above it.
By their numbers in this assay, from the lowest: compounds 3 and 4 (each within the scatter of the next); then compound 1; then compound 2.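

In this assay, the result shows that a low number at this position is not tied to the 2,6-dichlorophenyl group alone, with no change at the digits printed from compound 3 to compound 4 (within the scatter). The 3,5-difluorophenyl group also stands well short of both bromine-bearing groups, with a number 72 percentage points lower from compound 2 to compound 4 (beyond the scatter) and a number 45 percentage points lower from compound 1 to compound 4 (beyond the scatter). Nothing measured here explains this difference. Going by these compounds, it remains open whether bromine itself is what separates these groups. Also open, on these data alone, is what a phenyl ring carrying a single chlorine, an amine or a carboxylic acid would give at this position.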